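Varying the Aryl Group on the Ring Amide Nitrogen

A few compounds are considered here, and "the series" means these few. Any claim that something is new, unique, unknown or untested is made for them only; others in the source may bear on it.

Compound 1 `O=C1c2cc(COc3ccccc3)nn2CCN1c1ccccc1F` gives 86% in a functional assay on HEK293 cells for positive allosteric modulation of metabotropic glutamate receptor 5 (Homo sapiens), read by calcium flux; on this read-out lower numbers stand for smaller maximal responses and higher numbers for larger maximal responses.
Compound 2 `COc1ccc(N2CCn3nc(COc4ccccc4)cc3C2=O)cc1` gives 58% in this assay.
Compound 3 `O=C1c2cc(COc3ccccc3)nn2CCN1c1cccnc1` gives 64% in this assay.

Three compounds share one core and differ only in the aryl group on an amide-type nitrogen in a ring. Compound 3 stands second highest of the three numbers; its nearest neighbour is compound 2, which lies within the scatter, and its furthest is compound 1, whose maximal response is beyond the scatter higher, as the step of a number 22 percentage points lower from compound 1 to compound 3 (beyond the scatter) shows. The step of a number 6 percentage points higher from compound 2 to compound 3 (within the scatter) is within the scatter, so compounds 2 and 3 cannot be told apart.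

Compound 4 `O=C1c2cc(COc3ccccc3)nn2CCN1c1ccc(F)cn1` has not yet been measured. It differs from compound 3 in this way: 5-fluoropyridin-2-yl in place of pyridin-3-yl on an amide-type nitrogen in a ring. Within the data shown here, the steps that bear on this change are a number 22 percentage points lower from compound 1 to compound 3 (beyond the scatter) and a number 6 percentage points higher from compound 2 to compound 3 (within the scatter): one aryl exchange at this nitrogen moved the maximal response modestly, the other not beyond the scatter. A change of the same kind is therefore expected to give compound 4 a step of a number 2 percentage points higher from compound 3 to compound 4 (within the scatter) in this assay, which could fall on either side of the scatter. Compound 4 is estimated at 66%, with a range from 46% to 86%.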

Compound 4, largest response reached (Emax), in percent of the reference or control that the assay uses: 72%
Compound 4: the middle estimate sits 6 percentage points below what was measured, and the stated range covers the measured number.
By their numbers in this assay, from the lowest: compounds 2, 3 and 4 (each within the scatter of the next, the first and the last beyond it); then compound 1.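

In this assay, moving from pyridin-3-yl to 5-fluoropyridin-2-yl on the amide-type nitrogen leaves the maximal response unresolved (a number 8 percentage points higher from compound 3 to compound 4 (within the scatter)), so a second pyridine-type ring cannot be told apart from the first. Compound 4 nevertheless does what compound 3 did not: it separates from the 4-methoxyphenyl compound (a number 14 percentage points higher from compound 2 to compound 4 (beyond the scatter)) while still remaining separate from the 2-fluorophenyl compound (a number 14 percentage points lower from compound 1 to compound 4 (beyond the scatter)), which places it at an intermediate level that is distinct from both phenyl compounds. Nothing shown here explains why these aryl groups differ, and no supporting measurement bears on this result.

The exchange from compound 3 to compound 4 alters both the attachment of the pyridine ring and the presence of fluorine, so the compounds shown do not separate the contribution of either change, which pyridin-2-yl without fluorine could help to resolve. They also leave open how an unsubstituted phenyl, a 5-chloropyridin-2-yl or a saturated ring such as cyclohexyl would behave on this nitrogen.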